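The source may hold more compounds than are shown below. What is called first, only, known or untested is meant among the compounds shown, and "the series" means these compounds.

Compound 1 `Cc1ccc(-c2cc(-c3ccc(Cl)o3)cc(-c3ccsc3)n2)o1`: > 50000 nM
Compound 2 `Clc1ccc(-c2cc(-c3ccoc3)cc(-c3ccsc3)n2)cc1`: > 100000 nM

In a functional assay on HCT-15 cells (Homo sapiens) for cytotoxicity, in the presence of a further agent that is not named here (a lower number here means a stronger inhibitor, a higher number a weaker inhibitor), compound 1 gives only a limit, > 50000 nM, and not a number. Compound 2 also gives only a limit there, > 100000 nM. Going by the values given here, the two values shown are thus both limits, one sitting at the limit of > 50000 nM in this assay, at which 1 of the 2 values shown sits, and the other at the limit of > 100000 nM in this assay, at which 1 of the 2 values shown sits, and no step between the two compounds is counted; compound 1 therefore stands simply as a compound with a limit and nothing more. Compound 3 `Clc1ccc(-c2cc(-c3ccsc3)nc(-c3ccco3)c2)o1` is not yet measured. It differs from compound 1 in one place: hydrogen in place of methyl on an aromatic carbon. Put one bond further out, the 5-methylfuran-2-yl of compound 1 becomes furan-2-yl. Because > 50000 nM for compound 1 is only a limit, the step that the limit leaves unreadable from compound 1 to compound 3 is expected to be none beyond the scatter. Compound 3 is expected to give about 80000 nM, within 20000 nM to 300000 nM, and most likely again only as a limit.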

Compound 3, half-maximal inhibitory concentration: > 50000 nM
Compound 3 was reported as a limit; the forecaster's own chance of this, stated with the estimate: 85%; the middle value lies beyond the limit too.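

Going by these compounds alone, compound 3 gives only a limit in this assay, > 50000 nM, so no step from compound 1 to compound 3 can be read. The compounds shown leave open what any of them would give as an actual number in this assay, and so whether 5-methylfuran-2-yl or furan-2-yl makes any difference there.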